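Two Methoxy Groups in Place of Trifluoromethyl

The compounds below may be only part of what the source reports. "The series", "measured", "known", "first", "only" and "open" are said of these compounds alone.

Compound 1 `O=C(NCc1cn(Cc2ccc(C(F)(F)F)cc2)nn1)c1cn(-c2ccccc2)nc1-c1ccccc1` gives 1600 nM in a functional assay on HeLa cells (Homo sapiens) for antiproliferative activity, read by sulforhodamine B assay, with a stated time of 48 h (a higher number here means a weaker inhibitor of growth, a lower number a stronger inhibitor of growth), the lowest of the two numbers measured. Compound 2 `COc1ccc(Cn2cc(CNC(=O)c3cn(-c4ccccc4)nc3-c3ccccc3)nn2)cc1` gives 6900 nM, and the step of a 4.3-fold higher number from compound 1 to compound 2 (0.63 log units; beyond the scatter) lies beyond the scatter. Compound 3 `COc1ccc(Cn2cc(CNC(=O)c3cn(-c4ccccc4)nc3-c3ccccc3)nn2)cc1OC` is the unmeasured partner; it differs from compound 1 by 3,4-dimethoxyphenyl in place of 4-(trifluoromethyl)phenyl on a saturated chain carbon bound to an aromatic nitrogen. Among the compounds with values here, the only step that bears on this change is the one from compound 1 to compound 2, which was modest and upward, so a step of similar size toward a higher number is expected, a 4.7-fold higher number from compound 1 to compound 3 (0.67 log units; beyond the scatter). Compound 3 is therefore estimated at 7500 nM, within 3000 nM to 20000 nM.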

Compound 3, concentration for 50% growth inhibition: 10800 nM
Beside the measured number, compound 3's estimate is 1.4-fold (0.16 log units) below it; low and high end bracket the measured number.
By their numbers in this assay, from the lowest: compound 1; then compounds 2 and 3 (each within the scatter of the next).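

In this assay, 3,4-dimethoxyphenyl in place of 4-(trifluoromethyl)phenyl gives a 6.8-fold higher number from compound 1 to compound 3 (0.83 log units; beyond the scatter), so the upward shift seen with one methoxy group also holds with two. Adding the second methoxy group gives a 1.6-fold higher number from compound 2 to compound 3 (0.19 log units; within the scatter), so compound 2 and compound 3 cannot be told apart here. Nothing measured here speaks to the reason for these steps.

As far as these compounds go, what stays open is whether a fluorine, a nitrile or an amine in place of trifluoromethyl would bring the number below that of compound 1 or raise it as methoxy does.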